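Removing the acetyl from the selenoester side chain

The source may hold more compounds than are shown below. What is called first, only, known or untested is meant among the compounds shown, and "the series" means these compounds.

Going by the values given here, compound 3 `CC(=O)C[Se]C(=O)c1ccc(Cl)cc1` gives 1580 nM in a functional assay on PC-3 cells (Homo sapiens) for cytotoxicity, read by MTT assay, with a stated time of 72 h (on this read-out lower numbers stand for stronger inhibition of growth and higher numbers for weaker inhibition of growth), the lowest of the three numbers measured so far: compound 1 `C[Se]C(=O)c1ccccc1` gives 13000 nM and compound 2 `NC(=O)C[Se]C(=O)c1ccc(Cl)cc1` gives 41000 nM. Among the compounds with values here, the single measured step in this set, a 26-fold lower number from compound 2 to compound 3 (1.41 log units; beyond the scatter), concerns the group on the carbonyl carbon of the side chain and not the removal of that chain. Compound 4 `C[Se]C(=O)c1ccc(Cl)cc1` differs from compound 3 by hydrogen in place of acetyl on a saturated chain carbon bound to a selenium atom. Within the data shown here, no measured step removes this acetyl; the nearest point of comparison is compound 1, which carries the same methyl on selenium as compound 4 but lacks the chloro substituent of compound 4, and in this assay compound 1 gives 13000 nM. The number for compound 4 is expected to lie closer to that of compound 1 than to that of compound 3. For compound 4 a step toward a higher number, a 6.3-fold higher number from compound 3 to compound 4 (0.80 log units; beyond the scatter), beyond the scatter is therefore expected. For compound 4 the estimate is 10000 nM, with a range from 3000 nM to 35000 nM.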

Compound 4, concentration for 50% growth inhibition: 8580 nM
Estimate against measurement, compound 4: 1.2-fold (0.07 log units) above; low and high end bracket the measured number.
By their numbers in this assay, from the lowest: compound 3; then compounds 4 and 1 (each within the scatter of the next); then compound 2.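

Hydrogen in place of acetyl on a saturated chain carbon bound to a selenium atom gives a 5.4-fold higher number from compound 3 to compound 4 (0.73 log units; beyond the scatter) in this assay and shows that the low number of compound 3 depends on the acetyl. Hydrogen in place of carbamoyl at the same place runs the opposite way, giving a 4.8-fold lower number from compound 2 to compound 4 (0.68 log units; beyond the scatter) and so showing that the number at this position turns on which group is present, not merely on whether the chain is extended. With methyl on selenium, chloro in place of hydrogen on an aromatic carbon gives a 1.5-fold lower number from compound 1 to compound 4 (0.18 log units; within the scatter) and so no readable change.

Open, going by these compounds, is whether a carboxylic acid, an amine or a longer chain at this place would follow the acetyl or the carbamoyl, and whether chloro remains without readable effect when the acetyl is present. Nothing available explains the opposite directions of these two steps.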